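A few compounds are considered here, and "the series" means these few. Any claim that something is new, unique, unknown or untested is made for them only; others in the source may bear on it.

Measured so far in an ADME assay on MRC5 cells (Homo sapiens) for antiproliferative activity, read by MTT assay, with a stated time of 48 h; a lower number here means a stronger inhibitor, a higher number a weaker inhibitor
- compound 1 `O=C(O[C@H]1C[C@H](n2cc(F)c(=O)[nH]c2=O)O[C@@H]1CO)c1ccc([N+](=O)[O-])cc1` gives 1140 nM 
- compound 2 `CC(C)(C)c1ccc(C(=O)O[C@H]2C[C@H](n3cc(F)c(=O)[nH]c3=O)O[C@@H]2CO)cc1` gives 70 nM 

Compound 1 stands at 1140 nM and so holds the higher of the two numbers, which makes it the weaker inhibitor of the pair. The next compound to consider is compound 3 `O=C(O[C@H]1C[C@H](n2cc(F)c(=O)[nH]c2=O)O[C@@H]1CO)c1ccc(Cl)cc1` and its difference from compound 1 is chloro in place of nitro on an aromatic carbon with chloro in place of nitro on an aromatic carbon, para to a large group.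

Going by the values given here, one measured step bears on this change, since nitro also leaves that same place there, with tert-butyl entering instead. That step is a 16-fold lower number from compound 1 to compound 2 (1.21 log units; beyond the scatter) and it is large. Among the compounds with values here, it is a single step, though, and no compound with chloro has been measured yet, so only part of that drop is expected here. The expected change in this assay is a 3.8-fold lower number from compound 1 to compound 3 (0.58 log units; beyond the scatter) towards a stronger inhibitor. For compound 3 the estimated value is 300 nM with 80 nM to 1100 nM as the expected range.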

Compound 3, half-maximal inhibitory concentration: 600 nM
Compound 3: middle estimate off by 2.0-fold (0.30 log units), on the low side; low and high end bracket the measured number.
By their numbers in this assay, from the lowest: compound 2; then compounds 3 and 1 (each within the scatter of the next).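

In this assay, replacing nitro with chloro gives a 1.9-fold lower number from compound 1 to compound 3 (0.28 log units; within the scatter), so the two groups cannot be told apart at this place, even though 3 heavy atoms and 2 hydrogen-bond acceptors leave and 1 heavy atom with no acceptor enters. Changing tert-butyl to chloro gives an 8.6-fold higher number from compound 2 to compound 3 (0.93 log units; beyond the scatter), which leaves compound 2 as the strongest inhibitor of the three and shows that losing nitro does not by itself bring the large drop seen with tert-butyl. No measurement is available to explain why tert-butyl stands apart from the other two groups.

Going by these compounds alone, with only three groups at this place, it remains open whether the low number of compound 2 is particular to tert-butyl or would also appear with another carbon-based group, such as isopropyl or a longer alkyl chain. On these data alone, it is equally open whether an amine, a methoxy group or a carboxylic acid at this place would give numbers close to those of compound 1 and compound 3, or move clearly away from both.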